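Chloro for hydrogen on the benzylidene ring of compound 2

A few compounds are considered here, and "the series" means these few. Any claim that something is new, unique, unknown or untested is made for them only; others in the source may bear on it.

Measured so far:
- compound 1, `COc1ccccc1/C=N/c1c(C)n(C)n(-c2ccccc2)c1=O`, 229000000 nM
- compound 2, `Cc1c(/N=C/c2ccccc2)c(=O)n(-c2ccccc2)n1C`, 240000000 nM

In a functional assay on P388 cells (Mus musculus) for cytotoxicity, read by MTT assay, with a stated time of 72 h (a higher number here means a weaker inhibitor, a lower number a stronger inhibitor), compound 2 gives 240000000 nM, the higher of the two numbers seen, but its neighbour compound 1 sits within the scatter of it. Among the compounds with values here, the one measured step, a 1.0-fold higher number from compound 1 to compound 2 (0.02 log units; within the scatter), shows that removing the methoxy group left the number essentially unchanged.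

Compound 3, `Cc1c(/N=C/c2ccc(Cl)cc2)c(=O)n(-c2ccccc2)n1C`, is not yet measured. Its change against compound 2 is chloro in place of hydrogen on an aromatic carbon. Within the data shown here, no measured step touches a chloro substituent, so nothing here bears directly on this change; the only step known, a 1.0-fold higher number from compound 1 to compound 2 (0.02 log units; within the scatter), concerned a different group on the same ring and stayed within the scatter.

With that, no step beyond the scatter is expected: compound 3 is estimated at 230000000 nM (range 90000000 nM to 600000000 nM), a step of a 1.0-fold lower number from compound 2 to compound 3 (0.02 log units; within the scatter).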

Compound 3, half-maximal inhibitory concentration: 646000000 nM
Beside the measured number, compound 3's estimate is 2.8-fold (0.45 log units) below it; measured number above the stated range.
By their numbers in this assay, from the lowest: compounds 1 and 2 (each within the scatter of the next); then compound 3.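

Chloro in place of hydrogen, para to a large group, gives the first step in the series beyond the scatter in this assay: a 2.7-fold higher number from compound 2 to compound 3 (0.43 log units; beyond the scatter), towards a weaker inhibitor. The swap of 4-chlorophenyl in place of 2-methoxyphenyl points the same way with a 2.8-fold higher number from compound 1 to compound 3 (0.45 log units; beyond the scatter), whereas a 1.0-fold higher number from compound 1 to compound 2 (0.02 log units; within the scatter) stayed within the scatter, so this ring is not indifferent to every substituent, although the shift is modest. Nothing available on these compounds accounts for the shift.

Whether the shift belongs to chloro itself or to any group at this place stays open, since only one substituent is shown there; a methoxy, an amine or a carboxylic acid at the same carbon would separate the two readings. Also open, from the compounds shown here alone, is whether any change to this ring can give a lower number than compound 1 and compound 2 show.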